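The source may report more compounds than this note shows. Statements on the series, on what has been measured and on what is new or still open speak of the compounds shown alone.

The measured compounds:
Compound 1, `Nc1nc(=O)ccn1[C@@H]1O[C@H](COP(=O)(O)OP(=O)(O)O)[C@@H](O)[C@H]1O`, in an in vitro functional assay on 1321-N1 cells for agonist activity at P2Y purinoceptor 4 (Homo sapiens), read by scintillation proximity assay and inositol phosphate accumulation (on this read-out higher numbers stand for an effect only at larger amounts of compound and lower numbers for an effect already at smaller amounts), gives >= 100000 nM, which is a limit of the assay rather than a number.
Compound 2, `CCSc1nc(=O)ccn1[C@@H]1O[C@H](COP(=O)(O)O)[C@@H](O)[C@H]1O`, in this assay gives 4330 nM.
Compound 3, `CNc1nc(=O)ccn1[C@@H]1O[C@H](COP(=O)(O)O)[C@@H](O)[C@H]1O`, in this assay gives > 100000 nM, again a limit of the assay and not a number.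

Compound 3 thus stands at the upper limit of this assay, with no measured number of its own. Among the measured compounds shown here, the only measured step that reaches it is an at least 23-fold higher number from compound 2 to compound 3 (1.36 log units; beyond the scatter), so the methylamino compound is already beyond what the assay can resolve; the limits at the limit of > 100000 nM in this assay, at which 1 of the 3 values shown sits, and the limit of >= 100000 nM in this assay, at which 1 of the 3 values shown sits, are where compound 3 and compound 1 sit.

The change now considered is hydrogen in place of methyl on a nitrogen on an aromatic ring, which gives compound 4, `Nc1nc(=O)ccn1[C@@H]1O[C@H](COP(=O)(O)O)[C@@H](O)[C@H]1O`. For the measured compounds named here, no measured step covers this change directly. What can be said is that compound 1, which carries the same amino group but a diphosphate, also sits at a limit, and that compound 3 itself starts at a limit, so a further decrease could not be seen in this assay.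

Compound 4 is therefore expected to remain at the limit of this assay, estimated at 100000 nM (range 30000 nM to 300000 nM). The expected step of a number no higher from compound 3 to compound 4 (the limit leaves the size open) is accordingly none beyond the scatter.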

Compound 4, half-maximal effective concentration: 4980 nM
Compound 4: middle estimate off by 20-fold (1.30 log units), on the high side; the whole stated range lies above it.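

In this assay, hydrogen in place of methyl on the nitrogen gives an at least 20-fold lower number from compound 3 to compound 4 (1.30 log units; beyond the scatter), so this single methyl separates a measured value from a limit of the assay: the limit of > 100000 nM in this assay, at which 1 of the 4 values shown sits.

With amino and ethylsulfanyl on this aromatic carbon, the step is a 1.2-fold higher number from compound 2 to compound 4 (0.06 log units; within the scatter), so the two groups are not told apart here and a measurable effect does not depend on the sulfur-linked chain. The phosphate end also counts with the amino group in place, since a hydrogen atom in place of the outer phosphate group of the diphosphate gives an at least 20-fold lower number from compound 1 to compound 4 (1.30 log units; beyond the scatter), again starting from a limit of the assay: the limit of >= 100000 nM in this assay, at which 1 of the 4 values shown sits.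

The compounds shown leave open how far compound 3 and compound 1 lie beyond their limits, so the full size of both large steps remains unknown. They also leave open whether an ethylamino group, a dimethylamino group or a hydroxyl group on this aromatic carbon would behave like amino or like methylamino, and what a diphosphate would do together with ethylsulfanyl.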